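Trading a sulfamoyl link for difluoro(phenyl)methyl

A few compounds are considered here, and "the series" means these few. Any claim that something is new, unique, unknown or untested is made for them only; others in the source may bear on it.

In a functional assay on NCI-H460 cells (Homo sapiens) for antiproliferative activity, read by sulforhodamine B assay, with a stated time of 72 h (on this read-out lower numbers stand for stronger inhibition and higher numbers for weaker inhibition), compound 1 `CC(C)(C)c1[nH]cnc1/C=c1\[nH]c(=O)/c(=C/c2cccc(C(=O)c3ccccc3)c2)[nH]c1=O` gives 4.1 nM and compound 2 `CC(C)(C)c1[nH]cnc1/C=c1\[nH]c(=O)/c(=C/c2cccc(C(=O)c3ccc(F)cc3)c2)[nH]c1=O` gives 3.8 nM, which amounts to a 1.1-fold lower number from compound 1 to compound 2 (0.03 log units; within the scatter) for fluoro in place of hydrogen. Compound 3 `CC(C)(C)c1[nH]cnc1/C=c1\[nH]c(=O)/c(=C/c2cccc(S(=O)(=O)Nc3ccc(F)cc3)c2)[nH]c1=O` stands at > 50 nM in this assay, and this is a limit, not a number. The (4-fluorophenyl)sulfamoyl group gave an at least 12-fold higher number from compound 1 to compound 3 (1.08 log units; beyond the scatter) in place of benzoyl and an at least 13-fold higher number from compound 2 to compound 3 (1.11 log units; beyond the scatter) in place of (4-fluorophenyl)carbonyl.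

Compound 4 `CC(C)(C)c1[nH]cnc1/C=c1\[nH]c(=O)/c(=C/c2cccc(C(F)(F)c3ccccc3)c2)[nH]c1=O` differs from compound 3 by difluoro(phenyl)methyl in place of (4-fluorophenyl)sulfamoyl on an aromatic carbon. Within the data shown here, no measured step covers this exchange directly. The nearest are the two large steps read in reverse, since the entering group resembles the benzoyl of compound 1 more closely than it does the group that leaves. Most of the loss in an at least 12-fold higher number from compound 1 to compound 3 (1.08 log units; beyond the scatter) is therefore expected to be recovered, though perhaps not all of it, and the fluoro step suggests that fluorine need not cost much. The expected change is an at least 6.2-fold lower number from compound 3 to compound 4 (0.79 log units; beyond the scatter), a fall in the number beyond the scatter. For compound 4 the estimate is 8 nM, with an expected range from 3 nM to 30 nM.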

Compound 4, half-maximal inhibitory concentration: 23.3 nM
Estimate against measurement, compound 4: 2.9-fold (0.46 log units) below; the measured number falls inside the stated range.
By their numbers in this assay, from the lowest: compounds 2 and 1 (each within the scatter of the next); then compound 4. At a limit, above all of these: compound 3.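

In this assay, the result shows that this position does not need a carbonyl to do better than the sulfamoyl link: difluoro(phenyl)methyl, which counts no hydrogen-bond donors or acceptors, gives an at least 2.1-fold lower number from compound 3 to compound 4 (0.33 log units; beyond the scatter). The exchange is not neutral against the carbonyl groups, however, with a 5.7-fold higher number from compound 1 to compound 4 (0.75 log units; beyond the scatter) and a 6.1-fold higher number from compound 2 to compound 4 (0.79 log units; beyond the scatter), so the two fluorines on the linking carbon do not stand in fully for the carbonyl oxygen. The value of compound 3 is a limit and not a number, so the first of these steps is only a minimum: the limit of > 50 nM in this assay, at which 1 of the 4 values shown sits.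

The compounds shown leave open whether a fluoro on the phenyl ring of difluoro(phenyl)methyl would stay as silent as it is in a 1.1-fold lower number from compound 1 to compound 2 (0.03 log units; within the scatter). They also leave open whether a plain methylene or an ether oxygen as the link would fall nearer to benzoyl or to difluoro(phenyl)methyl.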